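Methyl for Fluoro on the Cyclopropyl Amide

The source may report more compounds than this note shows. Statements on the series, on what has been measured and on what is new or still open speak of the compounds shown alone.

In an assay on CHO cells for displacement of a labelled ligand from Neuronal acetylcholine receptor; alpha3/alpha6/beta2/beta3 (Homo sapiens), read by scintillation counting (a lower number here means a stronger inhibitor, a higher number a weaker inhibitor), compound 3 `O=C([C@H]1C[C@H]1F)N1CC2CC(C1)N2` gives 27 nM, the lowest of the three numbers. Compound 2 `O=C(C1CCC1)N1CC2CC(C1)N2` gives 240 nM in this assay, and compound 1 `O=C(C1CC1)N1CC2CC1CN2`, which carries a different core, gives 10000 nM. Going by the values given here, the only measured step that bears on the amide substituent is an 8.9-fold lower number from compound 2 to compound 3 (0.95 log units; beyond the scatter). Compound 4 `C[C@@H]1C[C@@H]1C(=O)N1CC2CC(C1)N2` differs from compound 3 by methyl in place of fluoro on a saturated ring carbon. Among the compounds with values here, no measured pair exchanges a fluoro for a methyl, so the expectation rests on the modest size of that cyclobutyl-to-fluorocyclopropyl step alone. Compound 4 is expected to show a step of a 2.2-fold higher number from compound 3 to compound 4 (0.35 log units; beyond the scatter), a small shift toward a higher number that may well lie within the scatter. Compound 4 is therefore estimated at 60 nM, with a range from 15 nM to 300 nM.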

Compound 4, inhibition constant: 92 nM
Compound 4: the middle estimate sits 1.5-fold (0.19 log units) below what was measured, and the stated range covers the measured number.
By their numbers in this assay, from the lowest: compound 3; then compound 4; then compound 2; then compound 1.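

In this assay, the exchange shows a 3.4-fold higher number from compound 3 to compound 4 (0.53 log units; beyond the scatter), so this ring carbon is sensitive to methyl in place of fluoro, and the step is beyond the scatter. Methyl does not cancel the gain over the cyclobutyl amide, with a 2.6-fold lower number from compound 2 to compound 4 (0.42 log units; beyond the scatter) also beyond the scatter. Nothing at hand explains either step. The compounds shown leave open how a hydroxyl, a chloro or a trifluoromethyl would read on this ring carbon. They also leave open how the unsubstituted cyclopropyl amide reads on the shared core, as compound 1 has a different core.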